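The source may hold more compounds than are shown below. What is called first, only, known or untested is meant among the compounds shown, and "the series" means these compounds.

Within the data shown here, in a functional assay on HeLa cells (Homo sapiens) for inhibition, read by MTT assay, with a stated time of 72 h (on this read-out lower numbers stand for stronger inhibition and higher numbers for weaker inhibition), compound 1 `COc1ccc(-c2nnc(SCCCN3CCN(c4nc5ccccc5o4)CC3)o2)cc1` gives 210000 nM, which places it at the high end of the three numbers measured so far. Compound 2 `O=[N+]([O-])c1ccc(-c2nnc(SCCCN3CCN(c4nc5ccccc5o4)CC3)o2)cc1`, with nitro in place of methoxy on an aromatic carbon, gives 114000 nM, and this is a 1.8-fold lower number from compound 1 to compound 2 (0.27 log units; within the scatter). Compound 3 `Oc1ccc(-c2nnc(SCCCN3CCN(c4nc5ccccc5o4)CC3)o2)cc1`, with hydrogen in place of methyl on the oxygen, gives 99500 nM, which is a 2.1-fold lower number from compound 1 to compound 3 (0.32 log units; beyond the scatter). These two modified compounds barely separate, with a 1.1-fold lower number from compound 2 to compound 3 (0.06 log units; within the scatter).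

Compound 4 `COc1ccc(-c2nnc(SCCCN3CCN(c4nc5ccccc5s4)CC3)o2)cc1` keeps the methoxy group of compound 1 and changes a different part of the molecule: 1,3-benzothiazol-2-yl in place of 1,3-benzoxazol-2-yl on an amine nitrogen in a ring. In words, 1,3-benzothiazol-2-yl stands in place of 1,3-benzoxazol-2-yl on an amine nitrogen in a ring, so one oxygen gives way to one sulfur. Among the measured compounds shown here, no measured compound carries the 1,3-benzothiazol-2-yl group, so the data offer only indirect guidance. The measured steps all lie elsewhere in the molecule, and the largest of them is the modest 2.1-fold lower number from compound 1 to compound 3 (0.32 log units; beyond the scatter). A step of similar or smaller size is therefore expected, leaning toward lower numbers only tentatively. The expected step is a 1.6-fold lower number from compound 1 to compound 4 (0.21 log units; within the scatter). For compound 4 the estimated value is 130000 nM, with an expected range from 50000 nM to 300000 nM.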

Compound 4, half-maximal inhibitory concentration: 165000 nM
Compound 4: the middle estimate sits 1.3-fold (0.10 log units) below what was measured, and the stated range covers the measured number.
By their numbers in this assay, from the lowest: compounds 3, 2, 4 and 1 (each within the scatter of the next, the first and the last beyond it).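

In this assay, exchanging the 1,3-benzoxazol-2-yl group for the 1,3-benzothiazol-2-yl group on the amine nitrogen in a ring gives a 1.3-fold lower number from compound 1 to compound 4 (0.10 log units; within the scatter), the first step shown at this end of the molecule, and it leaves compound 4 and compound 1 indistinguishable. The two groups match in heavy-atom count, ring types and hydrogen-bond counts and differ only in one oxygen giving way to one sulfur, so this position accepts that single-atom exchange without a change that rises above the scatter. Nothing measured on these compounds bears on why the exchange makes so little difference.

Going by these compounds, because the two groups are so alike, it remains open whether this position matters at all, and a plain phenyl group or a small acetyl group on the same amine nitrogen would test that far more strongly. Also open, on these data alone, is whether the hydroxy group of compound 3 and the 1,3-benzothiazol-2-yl group of compound 4 would together give a number different from those of the compounds carrying each one alone.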